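The compounds below may be only part of what the source reports. "The series", "measured", "known", "first", "only" and "open" are said of these compounds alone.

Measured compounds in a physicochemical assay for lipophilicity, using the shake flask method, in phosphate buffer, measured as octanol-water partition, at pH 7.4; on this read-out lower numbers stand for lower lipophilicity and higher numbers for higher lipophilicity:
compound 1 `COc1cc(-c2cc(C(=O)O)c3ccccc3n2)ccc1OCC(=O)Nc1ccccc1F` — compound 1 gives 0.9
compound 2 `COc1cc(-c2cc(C(=O)O)c3ccccc3n2)ccc1OCC(=O)Nc1ccccc1Cl` — compound 2 gives 1.6
compound 3 `COc1cc(-c2cc(C(=O)O)c3ccccc3n2)ccc1OCC(=O)Nc1cccc(Cl)c1` — compound 3 gives 2.3

Compound 2 sits in the middle of the three numbers in this assay: a number 0.70 log units higher from compound 2 to compound 3 (beyond the scatter), and a number 0.70 log units higher from compound 1 to compound 2 (beyond the scatter). The whole measured spread runs as a number 1.40 log units higher from compound 1 to compound 3 (beyond the scatter).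

Compound 4 `COc1cc(-c2cc(C(=O)O)c3ccccc3n2)ccc1OCC(=O)NCc1cccnc1` is not yet measured. Its difference from compound 2 is (pyridin-3-yl)methyl in place of 2-chlorophenyl on an amide-type nitrogen. Among the measured compounds shown here, none of the measured steps shows this change directly; they only vary the halogen and its position on the phenyl of the amide. The step that bears on it most is the one from fluoro to chloro, a number 0.70 log units higher from compound 1 to compound 2 (beyond the scatter), where a chlorine entering raised the number; in compound 4 the chlorine leaves altogether, and a ring with one hetero atom and one hydrogen-bond acceptor enters in place of a ring of carbon only. On that basis a step downward in this assay beyond the scatter is expected, larger than the halogen swap alone, about a number 1.20 log units lower from compound 2 to compound 4 (beyond the scatter). For compound 4 the expected value is 0.4, within a range from -0.4 to 1.2.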

Compound 4, distribution coefficient: -0.8
Beside the measured number, compound 4's estimate is 1.20 log units above it, outside the stated range (below it).
By their numbers in this assay, from the lowest: compound 4; then compound 1; then compound 2; then compound 3.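

In this assay, the amide-type nitrogen proves able to carry a much wider range of numbers than the halogen swaps showed: the read-out falls by a number 2.40 log units lower from compound 2 to compound 4 (beyond the scatter) and by a number 3.10 log units lower from compound 3 to compound 4 (beyond the scatter) and also by a number 1.70 log units lower from compound 1 to compound 4 (beyond the scatter) when (pyridin-3-yl)methyl replaces the halogen-bearing phenyl group. All three steps are large and beyond the scatter, which places compound 4 lowest of the four and shows that replacing the entire group at this position, with its ring carbon traded for a ring nitrogen and its halogen gone, can take the series well under the range set by the three halogenated phenyl amides. The data shown offer no measured explanation for the size of these steps.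

The change joins three alterations in one: the halogen leaves, a ring nitrogen enters and a carbon link appears between the ring and the amide-type nitrogen, and the four compounds cannot divide the step among them. A benzyl group and a pyridin-3-yl group placed directly on that nitrogen would separate the carbon link from the ring nitrogen, while a primary amine on a longer chain at the same place would test a different kind of group altogether.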